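A few compounds are considered here, and "the series" means these few. Any claim that something is new, unique, unknown or untested is made for them only; others in the source may bear on it.

In a functional assay on BXPC-3 cells (Homo sapiens) for inhibition, read by MTT assay, with a stated time of 7 days (on this read-out higher numbers stand for weaker inhibition and lower numbers for stronger inhibition), compound 2 `CCN(CC)S(=O)(=O)c1ccc(S(=O)(=O)N2CCC[C@@H](C(=O)NC3CN(C(=O)C4CC4)C3)C2)cc1` gives 18500 nM. Compound 1 `CCOC(=O)[C@@H]1CCC[C@@H](S(=O)(=O)c2ccc(S(=O)(=O)N(CC)CC)cc2)C1` gives 18500 nM, which matches compound 2 at the digits shown, so the two sit together at the top of the three numbers. Compound 3 `CCOC(=O)[C@@H]1CCCN(S(=O)(=O)c2ccc(S(=N)(=O)N(CC)CC)cc2)C1` gives 3600 nM, a gap from compound 2 that lies beyond the usual scatter, so compound 3 carries the lowest number of the three. Compound 4 `CCN(CC)S(=O)(=O)c1ccc(S(=O)(=O)N2CCC[C@@H](C(=O)NC3CN(S(C)(=O)=O)C3)C2)cc1` differs from compound 2 in one place: methylsulfonyl in place of cyclopropylcarbonyl on an amine nitrogen in a ring. For the measured compounds named here, no measured pair shows this change, so nothing here tells how this assay responds to it, and no step beyond the scatter is expected. Because compound 2 gives 18500 nM, compound 4 is expected at 18500 nM, within 7000 nM to 45000 nM. The step of no change at the digits printed from compound 2 to compound 4 (within the scatter) is expected to stay within the scatter.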

Compound 4, half-maximal inhibitory concentration: 7400 nM
Beside the measured number, compound 4's estimate is 2.5-fold (0.40 log units) above it; the range from low to high includes it.
By their numbers in this assay, from the lowest: compound 3; then compound 4; then compounds 1 and 2 (each within the scatter of the next).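

In this assay, methylsulfonyl in place of cyclopropylcarbonyl gives a 2.5-fold lower number from compound 2 to compound 4 (0.40 log units; beyond the scatter), a modest step. For the compounds shown here, this shows that the group on this amine nitrogen in a four-membered non-aromatic ring can shift the number, something the earlier compounds, which differ in more than one place, could not show. Nothing available explains the step. As far as these compounds go, whether it comes from the sulfonyl group or from the loss of the three-membered ring remains open. An acetyl or ethylsulfonyl group on the same nitrogen would help separate the two.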